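The compounds below may be only part of what the source reports. "The series", "measured", "known", "first", "only" and "open" are said of these compounds alone.

Measured so far:
- compound 1, `CC(C)=CC[C@@H](OCCO)C1=CC(=O)c2c(O)ccc(O)c2C1=O`: 9900 nM
- compound 2, `CCC(O)CO[C@H](CC=C(C)C)C1=CC(=O)c2c(O)ccc(O)c2C1=O`: 16400 nM

Both compounds were tested in a functional assay on DU-145 cells (Homo sapiens) for cytotoxicity, read by MTT assay; a lower number here means a stronger inhibitor, a higher number a weaker inhibitor. Compound 1 gives 9900 nM there, and compound 2 gives 16400 nM. Going by the values given here, only two numbers exist, and they sit within the usual scatter of each other: the single measured step, a 1.7-fold higher number from compound 1 to compound 2 (0.22 log units; within the scatter), brought an ethyl group in place of a hydrogen on a saturated chain carbon next to the ether oxygen and moved the number by no more than repeated measurements would.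

Compound 3, `CCC(CO[C@H](CC=C(C)C)C1=CC(=O)c2c(O)ccc(O)c2C1=O)OC`, has not yet been tested. It differs from compound 2 by methyl in place of hydrogen on an oxygen on a saturated carbon.

Among the compounds with values here, the only step that bears on this change is the one from compound 1 to compound 2, since it also altered the side chain that carries the hydroxy group, and that step stayed within the scatter. On the evidence of that step, no shift beyond the scatter is expected in this assay either way. The expected step is a 1.0-fold lower number from compound 2 to compound 3 (0.01 log units; within the scatter). Compound 3 is therefore estimated at 16000 nM, within a range from 7000 nM to 36000 nM.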

Compound 3, half-maximal inhibitory concentration: 45700 nM
Beside the measured number, compound 3's estimate is 2.9-fold (0.46 log units) below it, and the stated range ends below it.
By their numbers in this assay, from the lowest: compounds 1 and 2 (each within the scatter of the next); then compound 3.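

In this assay, going by these compounds alone, turning the hydroxy group of the side chain into a methoxy group gives the first single change here that clears the scatter (a 2.8-fold higher number from compound 2 to compound 3 (0.45 log units; beyond the scatter)), whereas adding an ethyl group to the same chain did not (a 1.7-fold higher number from compound 1 to compound 2 (0.22 log units; within the scatter)). The oxygen on this chain is therefore a place where a small edit counts: one methyl in place of one hydrogen makes compound 3 a weaker inhibitor than compound 2, and the full change in the side chain from the simplest compound shown also lies beyond the scatter (a 4.6-fold higher number from compound 1 to compound 3 (0.66 log units; beyond the scatter)). Nothing available gives a measured reason for this shift.

The compounds shown leave open whether the result depends on losing the hydrogen on that oxygen or on adding the carbon, and an amine in place of the hydroxy group or a longer ethoxy group in place of the methoxy group would help separate the two. As far as these compounds go, it also remains open whether the same methyl would matter on the shorter chain of compound 1, which has no ethyl group.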